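Chain Length on the Thioether of a Uridine Diphosphate

The source may hold more compounds than are shown below. What is called first, only, known or untested is meant among the compounds shown, and "the series" means these compounds.

Measured compounds:
compound 1 `O=c1cc(I)n([C@@H]2O[C@H](COP(=O)(O)OP(=O)(O)O)[C@@H](O)[C@H]2O)c(=O)[nH]1`, 15 nM
compound 2 `O=c1ccn([C@]23CC2[C@H](COP(=O)(O)OP(=O)(O)O)[C@@H](O)C3)c(=O)[nH]1`, 230 nM
compound 3 `C=CCSc1ccn([C@@H]2O[C@H](COP(=O)(O)OP(=O)(O)O)[C@@H](O)[C@H]2O)c(=O)n1`, 560 nM

Three compounds have been characterized in an in vitro functional assay on 1321-N1 cells for agonist activity at P2Y purinoceptor 6 (Homo sapiens); on this read-out lower numbers stand for an effect already at smaller amounts and higher numbers for an effect only at larger amounts of compound. Compound 1 gives 15 nM, the lowest of the three numbers. Compound 2 gives 230 nM. Compound 3 gives 560 nM, the highest number in this assay; its nearest neighbour is compound 2, and the gap to it already lies beyond the usual scatter, while compound 1 stands furthest away, well beyond the scatter. No two of these compounds differ in only one place, so no single step between measured compounds can be read from them.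

Compound 4 `CCCCCCSc1ccn([C@@H]2O[C@H](COP(=O)(O)OP(=O)(O)O)[C@@H](O)[C@H]2O)c(=O)n1` has not yet been measured. It differs from compound 3 in one place: pentyl in place of vinyl on a saturated chain carbon bound to a sulfur. Among the measured compounds shown here, nothing among the measured compounds shows how a longer chain at this position affects the read-out. Compound 4 is therefore expected to stay close to compound 3, with at most a modest shift toward a higher number, so that the step of a 1.4-fold higher number from compound 3 to compound 4 (0.15 log units; within the scatter) is estimated to be small and not clearly beyond the scatter. The estimate for compound 4 in this assay is 800 nM, within a range from 250 nM to 2500 nM.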

Compound 4, half-maximal effective concentration: 4900 nM
The estimate for compound 4 lay 6.1-fold (0.79 log units) below the measured number; the measured number lies above the stated range.
By their numbers in this assay, from the lowest: compound 1; then compound 2; then compound 3; then compound 4.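

In this assay the change from vinyl to pentyl on a saturated chain carbon bound to a sulfur gives an 8.8-fold higher number from compound 3 to compound 4 (0.94 log units; beyond the scatter) and lies beyond the scatter, which shows that the read-out at this position depends on what the sulfur carries. The change is a double one, however, because the chain grows and the double bond outside aromatic rings is lost in the same step, and this single pair cannot separate those two differences. Nothing in the available data explains the size of the step.

The compounds shown leave open whether the number climbs steadily with chain length or jumps beyond a certain length, and whether the double bond matters in its own right. A propyl chain on the sulfur would bear on the double bond, a butyl chain would fill in the path towards hexylsulfanyl, and a benzyl group or a chain ending in a carboxylic acid would show whether other groups at this place follow the same course.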